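This account rests on a few compounds, and the source may have more. Where it says the series, first, only, none or still open, it means among the compounds named here.

For the measured compounds named here, compound 2 `Nc1nc(Nc2ccc(S(N)(=O)=O)cc2)ccc1C(=O)c1c(F)cccc1F` is one of two compounds measured in a functional assay on A-375 cells (Homo sapiens) for antiproliferative activity (a higher number here means a weaker inhibitor, a lower number a stronger inhibitor), and it holds the only number there. In this assay compound 2 gives 6500 nM. Compound 1 `CN(C)S(=O)(=O)c1ccc(Nc2ccc(C(=O)c3c(F)cccc3F)c(N)n2)cc1` gives only a limit of the assay, > 10000 nM, not a number (the limit of > 10000 nM in this assay, at which 1 of the 2 values shown sits). Going by the values given here, the one measured step, an at least 1.5-fold lower number from compound 1 to compound 2 (0.18 log units; that floor lies within the scatter), concerns the group on the sulfonyl sulfur and nothing else.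

Compound 3 `CCCCOc1cc(Nc2ccc(S(N)(=O)=O)cc2)nc(N)c1C(=O)c1c(F)cccc1F` differs from compound 2 at a different place: butoxy in place of hydrogen on an aromatic carbon, in words butoxy in place of hydrogen on an aromatic carbon. Among the compounds with values here, none of the measured steps touches this part of the shared core, so the measured step from compound 1 to compound 2 offers no guide to its size or direction. With nothing to point either way, the expected step for compound 3 is a 1.3-fold lower number from compound 2 to compound 3 (0.11 log units; within the scatter), within the scatter. Compound 3 is therefore estimated at 5000 nM in this assay, with a range from 1000 nM to 20000 nM.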

Compound 3, half-maximal inhibitory concentration: 2900 nM
The estimate for compound 3 lay 1.7-fold (0.24 log units) above the measured number; the range from low to high includes it.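

In this assay, butoxy in place of hydrogen on the aromatic carbon opposite the ring nitrogen gives a 2.2-fold lower number from compound 2 to compound 3 (0.35 log units; beyond the scatter). For the compounds shown here, this is the first measured change at this part of the shared core, and it shows that the position can carry a chain of this size with no loss of activity; the only earlier step concerned the group on the sulfonyl sulfur. Nothing shown here accounts for why the number falls with this change.

Going by these compounds, how a methoxy group, a hexyloxy chain or a plain butyl chain with no oxygen would compare at this position remains open. Also open, on these data alone, is what butoxy would do with the dimethylamino group on the sulfonyl sulfur of compound 1, which gives only a limit of the assay, > 10000 nM.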